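The compounds below may be only part of what the source reports. "The series", "measured", "known", "first", "only" and "open" are said of these compounds alone.

Among the measured compounds shown here, compound 2 `CCc1ccc2nc(C(=O)Nc3c(F)cc(-c4cccc(F)c4)cc3F)c(C)c(O)c2c1` stands at the top of the two numbers so far: in a functional assay on Hep 3B2 cells (Homo sapiens) for antiproliferative activity, read by MTT assay, with a stated time of 24 h, tested at 3.7 ug/mL (on this read-out higher numbers stand for a stronger effect at the one concentration tested and lower numbers for a weaker effect), compound 2 gives 31.2%, and compound 1 `Cc1ccc2nc(C(=O)Nc3c(F)cc(-c4cccc(F)c4)cc3F)c(C)c(O)c2c1` gives 19.2%. For the measured compounds named here, the single measured step, a number 12 percentage points higher from compound 1 to compound 2 (beyond the scatter), is the only comparison in hand. Compound 3 `Cc1c(C(=O)Nc2c(F)cc(-c3cccc(F)c3)cc2F)nc2ccc(OC(F)(F)F)cc2c1O` differs from compound 2 by trifluoromethoxy in place of ethyl on an aromatic carbon. Going by the values given here, no measured step exchanges ethyl for trifluoromethoxy, so the step to compound 3 is expected to stay within the scatter, an estimated change of a number 1.2 percentage points lower from compound 2 to compound 3 (within the scatter). Compound 3 is therefore estimated at 30%, with a range from 14% to 48%.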

Compound 3, a percentage reported as inhibition, at one concentration (the size of the read-out at that concentration, not a potency): 26.4%
Compound 3: the middle estimate sits 3.6 percentage points above what was measured; the measured number falls inside the stated range.
By their numbers in this assay, from the lowest: compounds 1, 3 and 2 (each within the scatter of the next, the first and the last beyond it).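

In this assay, trifluoromethoxy on this aromatic carbon gives a number 4.8 percentage points lower from compound 2 to compound 3 (within the scatter) against ethyl and a number 7.2 percentage points higher from compound 1 to compound 3 (within the scatter) against methyl. Compound 3 thus cannot be separated from either compound 1 or compound 2, although those two differ beyond the scatter, so a group of five heavy atoms bearing oxygen and fluorine is accommodated here without a readable loss. No measurement at hand explains these numbers. Going by these compounds, whether an amine, a carboxylic acid or a longer alkyl chain on this carbon would stand apart from these three remains open.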